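2,3,4-Trifluorophenyl for 2,4-dichlorophenyl at the assay limit

This account rests on a few compounds, and the source may have more. Where it says the series, first, only, none or still open, it means among the compounds named here.

In a functional assay on HOS cells (Homo sapiens) for antiproliferative activity, with a stated time of 72 h (on this read-out higher numbers stand for weaker inhibition and lower numbers for stronger inhibition), compound 1 (`Cc1cccc(CNc2ncnc3c2ncn3[C@@H]2O[C@H](CO)[C@@H](O)[C@H]2O)c1`) gives > 166000 nM as a limit of the assay. Compound 2 (`OC[C@H]1O[C@@H](n2cnc3c(NCc4ccc(Cl)cc4Cl)ncnc32)[C@H](O)[C@@H]1O`) gives > 166000 nM as a limit too. Compound 3 (`OC[C@H]1O[C@@H](n2cnc3c(NCc4ccc(F)c(F)c4F)ncnc32)[C@H](O)[C@@H]1O`) carries 2,3,4-trifluorophenyl in place of 2,4-dichlorophenyl on a saturated chain carbon bound to a nitrogen on an aromatic ring. Within the data shown here, the only measured step (a step that the two limits leave unreadable from compound 1 to compound 2) has no readable size, and compound 1 and compound 2 both sit at the same limit (the limit of > 166000 nM in this assay, at which 2 of the 2 values shown sit). No step beyond the scatter is therefore expected in this assay and the estimated step is a number no higher from compound 2 to compound 3 (the limit leaves the size open) with no readable direction. For compound 3 the estimated value is 166000 nM (expected range 60000 nM to 400000 nM) and a further limit is likely.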

Compound 3, half-maximal inhibitory concentration: > 166000 nM
Compound 3: only a limit was reported (the forecaster's own chance of this, stated with the estimate: 85%); the middle value sits exactly at the limit.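

No step can be read among compound 1, compound 2 and compound 3 in this assay, since all three values are limits: the limit of > 166000 nM in this assay, at which 3 of the 3 values shown sit. On these data alone, whether 3-methylphenyl, 2,4-dichlorophenyl and 2,3,4-trifluorophenyl differ at all on this read-out stays open.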